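Alkynyl replacements for bromine on the sulfonyl aryl ring

The source may report more compounds than this note shows. Statements on the series, on what has been measured and on what is new or still open speak of the compounds shown alone.

Measured so far:
compound 1 `CC(=O)Nc1nc(-c2cccc(NS(=O)(=O)c3cccc(Br)c3)c2)cs1` — 36%
compound 2 `C#Cc1ccc(S(=O)(=O)Nc2cccc(-c3csc(NC(C)=O)n3)c2)cc1` — 1.2%

In a functional assay on A-375 cells (Homo sapiens) for antiproliferative activity, read by trypan blue exclusion, with a stated time of 48 h, tested at 10 uM (a higher number here means a weaker effect of the compound at the concentration tested, a lower number a stronger effect), compound 1 stands highest of the two numbers; the nearest is compound 2, lower by a number 34.8 percentage points lower from compound 1 to compound 2 (beyond the scatter), a step beyond the scatter that comes with 4-ethynylphenyl in place of 3-bromophenyl on the sulfonyl sulfur.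

Compound 3 `CCCCCCC#Cc1cccc(S(=O)(=O)Nc2cccc(-c3csc(NC(C)=O)n3)c2)c1` is not yet measured. Relative to compound 1 the change is oct-1-yn-1-yl in place of bromo on an aromatic carbon, at a position described as meta to a large group. For the measured compounds named here, the only step that bears on it is the one from compound 1 to compound 2, which was large and in the stronger direction and also exchanged bromine for a triple bond, though there on a different carbon and without the hexyl extension. A step in the same direction, though not necessarily as large, is therefore expected for compound 3, estimated at a number 24 percentage points lower from compound 1 to compound 3 (beyond the scatter). Compound 3 is expected to give about 12%, within a range of 0% to 36%.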

Compound 3, a percentage reported as activity, at one concentration (the size of the read-out at that concentration, not a potency): < 1%
Compound 3: no number, only a limit; the forecaster's own chance of this, stated with the estimate: 0%; at least 11 percentage points between middle value and limit.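

In this assay, oct-1-yn-1-yl in place of bromo on the same aromatic carbon comes with a number at least 35 percentage points lower from compound 1 to compound 3 (beyond the scatter). Compound 3 reads < 1%, which is a limit of the assay and not a number: the limit of < 1% in this assay, at which 1 of the 3 values shown sits.

The step from compound 1 to compound 2 moved the group to a different carbon as well, whereas this one keeps the carbon, so it shows that this position accepts a group of 8 heavy atoms with no loss of effect at the concentration tested.

The reading stands at a limit. The data do not separate the triple bond from the chain behind it. A saturated octyl chain on this carbon, or a chain ending in an amine, would test how much of the effect depends on each.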